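Seleno-Substituted Fused Diazines: Working Notes on Growth Inhibition

The source may hold more compounds than are shown below. What is called first, only, known or untested is meant among the compounds shown, and "the series" means these compounds.

Measured compounds:
Compound 1 `[SeH]c1nc([SeH])c2ccccc2n1`: 65900 nM
Compound 2 `Nc1nc([SeH])nc2ncccc12`: 96600 nM
Compound 3 `[SeH]c1nc([SeH])c2cccnc2n1`: 7930 nM

All three were run in a functional assay on HTB-54 cells (Homo sapiens) for cytotoxicity, read by MTT assay, with a stated time of 72 h; on this read-out lower numbers stand for stronger inhibition of growth and higher numbers for weaker inhibition of growth. Within this set compound 3 gives the lowest number, 7930 nM. Compound 2 carries one change against compound 3, (one nitrogen atom in place of one selenium atom, on an aromatic carbon), and that single change brings a 12-fold higher number from compound 3 to compound 2 (1.09 log units; beyond the scatter). Compound 1 gives 65900 nM, which sits within the scatter of the number for compound 2, so no order between those two is claimed. Against compound 3, the number for compound 1 is higher by more than the scatter; the difference between the two cores of compound 1 and compound 3 is not broken down here.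

Compound 4 `Nc1nc([SeH])nc2ccccc12` is not yet measured. It differs from compound 1 by one nitrogen atom in place of one selenium atom, on an aromatic carbon, and the place of that change matches word for word the place of the change from compound 3 to compound 2, so this is the same change made on the core of compound 1. Going by the values given here, the expectation for compound 4 rests on that single precedent: the step from compound 1 to compound 4 is expected to be a 6.8-fold higher number from compound 1 to compound 4 (0.83 log units; beyond the scatter), in the same direction and of roughly the size of a 12-fold higher number from compound 3 to compound 2 (1.09 log units; beyond the scatter), with only one prior instance to support it. On that basis compound 4 is estimated at 450000 nM in this assay, with the expected range running from 120000 nM to 1500000 nM; a number this high may fall outside what the assay resolves.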

Compound 4, concentration for total growth inhibition: 3630 nM
Estimate against measurement, compound 4: 120-fold (2.09 log units) above; the measured number lies below the stated range.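

In this assay, the exchange of a selenium atom for an amino group, on an aromatic carbon of the six-membered aromatic ring with 2 nitrogen, gives an 18-fold lower number from compound 1 to compound 4 (1.26 log units; beyond the scatter). Set beside the earlier step, the same exchange runs in opposite directions on the two cores, so neither its direction nor its size can be carried from one core to the other in this series: the same change on two cores in this assay, a 12-fold higher number (1.09 log units; beyond the scatter) from compound 3 to compound 2 and an 18-fold lower number (1.26 log units; beyond the scatter) from compound 1 to compound 4, 220-fold (2.34 log units) apart, beyond the scatter of two such steps

Going by these compounds alone, with only one matched pair on each core, this shows that the outcome of the exchange differs between these two cores, but it does not show why the direction turns, and it gives no rule for predicting the step on a third core.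

The compounds shown leave open how a methylamino group, a hydroxyl group or a thiol would read at this place on either core, and whether any of them would follow the amino group on both. Every compound shown also keeps a selenium atom at the other substituted ring carbon, so an exchange at that carbon on either core remains an open question.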